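Ester to Amide at the Carbonyl of Compound 1

The compounds below may be only part of what the source reports. "The series", "measured", "known", "first", "only" and "open" are said of these compounds alone.

Measured compounds:
compound 1 `COC(=O)c1cc(-n2cc(-c3cc(OC)cc(OC)c3)nn2)ccc1O` — 3%
compound 2 `COC(=O)c1cc(-n2cc(-c3ccc(OC)cc3)nn2)ccc1O` — 16%
compound 3 `O=C(OCCCc1ccccc1)c1cc(-n2cc(-c3cc(O)ccc3O)nn2)ccc1O` — 81%

In a functional assay on CCRF-CEM cells (Homo sapiens) for inhibition, read by MTT assay, with a stated time of 2 days, tested at 10 uM (on this read-out higher numbers stand for more inhibition at the one concentration tested (going by the name of the read-out) and lower numbers for less inhibition), compound 1 gives 3%, the lowest of the three numbers. Compound 2 gives 16%, a number higher by more than the scatter, and compound 3 gives 81%, far above compound 1. No pair of these compounds differs in a single place, so none of the gaps can be tied to one change.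

Compound 4 `COc1cc(OC)cc(-c2cn(-c3ccc(O)c(C(=O)Nc4cccc(C(F)(F)F)c4)c3)nn2)c1` has not yet been measured. It differs from compound 1 in one place: (3-(trifluoromethyl)phenyl)amino in place of methoxy on a carbonyl carbon. Going by the values given here, nothing among the measured compounds isolates this change; compound 3 is the only one without a methyl ester, and it differs in a second place as well. The step from compound 1 to compound 4 is therefore expected to be modest and upward, a number 22 percentage points higher from compound 1 to compound 4 (beyond the scatter), though a step within the scatter cannot be ruled out. Compound 4 is expected to give 25%, with a range from 3% to 60%.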

Compound 4, a percentage reported as inhibition, at one concentration (the size of the read-out at that concentration, not a potency): 73%
Beside the measured number, compound 4's estimate is 48 percentage points below it; the measured number lies above the stated range.
By their numbers in this assay, from the lowest: compound 1; then compound 2; then compounds 4 and 3 (each within the scatter of the next).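

In this assay, the carbonyl carbon of compound 1 turns out to be a position that strongly affects the read-out: (3-(trifluoromethyl)phenyl)amino in place of methoxy gives a number 70 percentage points higher from compound 1 to compound 4 (beyond the scatter). Going by these compounds alone, this is the first change in the set that can be read at a single place, and it shows that the core of compound 1 can carry high inhibition at the one concentration tested when the methyl ester is replaced. The change adds an aromatic ring and a hydrogen-bond donor at once, and no measurement here bears on why the number rises.

It remains open whether the amide link or the trifluoromethyl group accounts for the step, as neither a plain phenylamino group nor a carboxylic acid at this carbonyl carbon appears among the compounds shown. Also open, going by these compounds, is whether the same replacement would act alike on compound 2.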